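A few compounds are considered here, and "the series" means these few. Any claim that something is new, unique, unknown or untested is made for them only; others in the source may bear on it.

Measured in an ADME assay, in phosphate buffer, at 28 degrees C, at pH 7.0; a higher number here means that the compound lasts longer, a lower number that the compound disappears faster:
compound 1 `CC(C)(C)OC(=O)[C@H](O)[C@H]1C(=O)N2C(C(=O)O)=C(C(C)(C)C)O[C@H]12` gives 10.7 h
compound 2 `CC(C)(C)C1=C(C(=O)O)N2C(=O)[C@H]([C@@H](O)c3ccc(O)cc3)[C@H]2O1` gives 10.3 h

Among the compounds with values here, compound 2 stands at the low end of these two numbers, with compound 1 as its only neighbour, but the step of a 1.0-fold lower number from compound 1 to compound 2 (0.02 log units; within the scatter) lies within the scatter, so the two half-lives count as the same. Compound 3 `Cn1cc([C@H](O)[C@H]2C(=O)N3C(C(=O)O)=C(C(C)(C)C)O[C@H]23)nn1` has not yet been measured. It differs from compound 2 in one place: 1-methyl-1H-1,2,3-triazol-4-yl in place of 4-hydroxyphenyl on a saturated chain carbon bound to an oxygen on a saturated carbon and a saturated ring carbon. Within the data shown here, the only measured step that touches the same place, a 1.0-fold lower number from compound 1 to compound 2 (0.02 log units; within the scatter), swapped one group for another on that saturated chain carbon and hardly moved the number. On that single piece of evidence a further swap at the same place is expected to leave the half-life roughly where it is, with no step beyond the scatter, a 1.0-fold lower number from compound 2 to compound 3 (0.01 log units; within the scatter). Compound 3 is therefore estimated at 10 h in this assay, within a range of 6 h to 17 h.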

Compound 3, half-life: 7 h
The estimate for compound 3 lay 1.4-fold (0.15 log units) above the measured number; the measured number falls inside the stated range.
By their numbers in this assay, from the lowest: compounds 3, 2 and 1 (each within the scatter of the next).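

In this assay, the saturated chain carbon bound to an oxygen on a saturated carbon and a saturated ring carbon has now carried three different groups, and all three half-lives lie within the scatter of one another. Putting 1-methyl-1H-1,2,3-triazol-4-yl in place of 4-hydroxyphenyl gives (a 1.5-fold lower number from compound 2 to compound 3 (0.17 log units; within the scatter)), and putting it in place of tert-butoxycarbonyl gives (a 1.5-fold lower number from compound 1 to compound 3 (0.18 log units; within the scatter)), so a five-membered aromatic ring with 3 hetero atoms and 0 hydrogen-bond donors fits the same range. No measurement shown here explains what sets this half-life.

On these data alone, whether a primary amine, a carboxylic acid or a longer alkyl chain on this carbon would also stay in this range remains open. So does whether changes elsewhere on the shared core would matter more.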